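A few compounds are considered here, and "the series" means these few. Any claim that something is new, unique, unknown or untested is made for them only; others in the source may bear on it.

Compound 1 `C[Se]c1nc(N)c2ccccc2n1` was tested in a functional assay on HTB-54 cells (Homo sapiens) for cytotoxicity, read by MTT assay, with a stated time of 72 h (a higher number here means a weaker inhibitor of growth, a lower number a stronger inhibitor of growth), where compound 1 gives 88700 nM. Going by the values given here, the only other measured compound, compound 2 `[SeH]c1nc([SeH])c2ccccc2n1`, gives in this assay 65900 nM, and the two numbers lie within the scatter of each other, so neither can be called the stronger. Compound 3 `CCCCC[Se]c1nc(N)c2ccccc2n1` differs from compound 1 by butyl in place of hydrogen on a saturated chain carbon bound to a selenium atom. Among the compounds with values here, no measured pair shows what such a lengthening of the chain does here, so only a small step, with no clear direction beyond the scatter, is expected. The expected step is a 1.5-fold lower number from compound 1 to compound 3 (0.17 log units; within the scatter). Compound 3 is estimated at 60000 nM, likely between 20000 nM and 150000 nM.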

Compound 3, concentration for total growth inhibition: 84000 nM
For compound 3 the middle estimate is 1.4-fold (0.15 log units) below the measured one; the range from low to high includes it.
By their numbers in this assay, from the lowest: compounds 2, 3 and 1 (each within the scatter of the next).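

Going from methyl to pentyl on selenium gives a 1.1-fold lower number from compound 1 to compound 3 (0.02 log units; within the scatter) in this assay, the first measured pair at this position. The two compounds cannot be told apart here, so adding butyl in place of hydrogen on this saturated chain carbon bound to a selenium atom shows no readable effect on growth inhibition. Nothing available explains this result.

On these data alone, whether a longer chain, a branched chain, or a chain ending in an amine or a carboxylic acid would shift the number beyond the scatter stays open. One pair also cannot show whether chains between methyl and pentyl behave the same way.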